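Side chain variation on the shared core

The source may report more compounds than this note shows. Statements on the series, on what has been measured and on what is new or still open speak of the compounds shown alone.

Compound 3 `NC(=O)C[C@H](NC(=O)c1cc2ccccc2cn1)C(=O)OCc1ccccc1` shows the highest of the three numbers, giving 216 nM in a functional assay on HeLa cells (Homo sapiens) for antiproliferative activity, read by MTT assay, with a stated time of 48 h (a lower number here means a stronger inhibitor, a higher number a weaker inhibitor), though its steps to the others lie within the scatter. Compound 2 `NC(=O)CC[C@H](NC(=O)c1cc2ccccc2cn1)C(=O)OCc1ccccc1` gives 181 nM and compound 1 `CC(C)[C@H](NC(=O)c1cc2ccccc2cn1)C(=O)OCc1ccccc1` gives 118 nM; the steps of a 1.5-fold higher number from compound 1 to compound 2 (0.19 log units; within the scatter), a 1.8-fold higher number from compound 1 to compound 3 (0.26 log units; within the scatter) and a 1.2-fold higher number from compound 2 to compound 3 (0.08 log units; within the scatter) are all small. Compound 4 `O=C(N[C@@H](CO)C(=O)OCc1ccccc1)c1cc2ccccc2cn1` differs from compound 3 by hydroxy in place of carbamoyl on a saturated chain carbon, two bonds along the chain from an amide-type nitrogen and a carbonyl carbon. Going by the values given here, no measured step removes the carbamoyl group outright; the nearest comparison is a 1.2-fold higher number from compound 2 to compound 3 (0.08 log units; within the scatter), which trades carbamoylmethyl for carbamoyl, and the exchange of isopropyl for carbamoylmethyl, a 1.8-fold higher number from compound 1 to compound 3 (0.26 log units; within the scatter), is similarly small. The step expected here is a 1.1-fold lower number from compound 3 to compound 4 (0.03 log units; within the scatter), within the scatter. Compound 4 is therefore estimated at 200 nM, with a range from 100 nM to 400 nM.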

Compound 4, half-maximal inhibitory concentration: 135 nM
Compound 4: middle estimate off by 1.5-fold (0.17 log units), on the high side; low and high end bracket the measured number.
By their numbers in this assay, from the lowest: compounds 1, 4, 2 and 3 (each within the scatter of the next).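

Hydroxy in place of carbamoyl gives a 1.6-fold lower number from compound 3 to compound 4 (0.20 log units; within the scatter), and hydroxy in place of carbamoylmethyl gives a 1.3-fold lower number from compound 2 to compound 4 (0.13 log units; within the scatter), so in this assay a hydroxymethyl side chain reads like the two chains carrying carbamoyl. Hydroxymethyl in place of isopropyl gives a 1.1-fold higher number from compound 1 to compound 4 (0.06 log units; within the scatter), which extends the same flat picture to the isopropyl compound, and no step among these four compounds leaves the scatter. Nothing available bears on why these side chains read alike. On these data alone, whether an amine, a carboxylic acid or a longer chain here would step beyond the scatter remains open.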